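The compounds below may be only part of what the source reports. "The series", "measured", "known", "first", "only" and "open" are said of these compounds alone.

Three amides share one core and differ only in the group on the amide nitrogen: compound 1 (`CCn1c(C(=O)NC(C)(C)CO)ccc1C(CC)(CC)c1ccc(OCS(=O)(=O)c2ccccc2)c(C)c1`), compound 2 (`CCn1c(C(=O)NC2(CO)CC2)ccc1C(CC)(CC)c1ccc(OCS(=O)(=O)c2ccccc2)c(C)c1`) and compound 3 (`CCn1c(C(=O)N[C@@H](CO)C(C)C)ccc1C(CC)(CC)c1ccc(OCS(=O)(=O)c2ccccc2)c(C)c1`). In a functional assay on BXPC-3 cells (Homo sapiens) for antiproliferative activity, read by MTT assay, with a stated time of 24 h (a higher number here means a weaker inhibitor, a lower number a stronger inhibitor), compound 3 gives 13200 nM, which lies within the scatter of compound 1 at 18300 nM, while compound 2 gives 45400 nM.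

Compound 4 (`CCn1c(C(=O)N[C@@H](CO)CCO)ccc1C(CC)(CC)c1ccc(OCS(=O)(=O)c2ccccc2)c(C)c1`) keeps the core of compound 3 and changes one group: 2-hydroxyethyl in place of isopropyl on a saturated chain carbon bound to an amide-type nitrogen and a saturated chain carbon. It carries 2-hydroxyethyl in place of isopropyl on a saturated chain carbon bound to an amide-type nitrogen and a saturated chain carbon.

Among the compounds with values here, three measured steps concern this same amide substituent: a 2.5-fold higher number from compound 1 to compound 2 (0.39 log units; beyond the scatter), a 1.4-fold lower number from compound 1 to compound 3 (0.14 log units; within the scatter) and a 3.4-fold lower number from compound 2 to compound 3 (0.54 log units; beyond the scatter). These steps are small to modest, but none of them brings in a 2-hydroxyethyl group, so they indicate a likely size better than a direction. Compound 3 stands at 13200 nM. Within the data shown here, no measured compound lies beyond the scatter on the lower side of compound 3, so a modest rise in this assay is expected rather than a fall, though this rests on very few data. The expected change is a 2.3-fold higher number from compound 3 to compound 4 (0.36 log units; beyond the scatter). The estimate for compound 4 is 30000 nM, with an expected range from 12000 nM to 70000 nM.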

Compound 4, half-maximal inhibitory concentration: > 50000 nM
Compound 4: a limit, no number; the forecaster's own chance of this, stated with the estimate: 12%; middle value at least 1.6-fold (0.22 log units) away from the limit.
By their numbers in this assay, from the lowest: compounds 3 and 1 (each within the scatter of the next); then compound 2. At a limit, above all of these: compound 4.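

In this assay, compound 4 gives a limit and not a number: the limit of > 50000 nM in this assay, at which 1 of the 4 values shown sits.

Within the data shown here, the exchange of isopropyl for 2-hydroxyethyl on this saturated chain carbon gives an at least 3.7-fold higher number from compound 3 to compound 4 (0.57 log units; beyond the scatter), and the whole amide substituent, compared with that of the earlier compounds, gives an at least 2.7-fold higher number from compound 1 to compound 4 (0.43 log units; beyond the scatter); the earlier steps only exchanged one carbon framework for another, whereas this one brings a hydrogen-bond donor and acceptor into this place and shows that the weaker side of the series can be reached by that exchange. Compared with the cyclopropyl-containing substituent the floor is only an at least 1.1-fold higher number from compound 2 to compound 4 (0.04 log units; that floor lies within the scatter), so that step alone does not separate compound 4 from compound 2 beyond the scatter, and how far compound 4 lies beyond any of them stays unknown.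

The compounds shown leave open whether the rise follows the hydroxyl itself or the two-carbon chain that carries it, which a plain n-propyl, a 2-methoxyethyl or a 2-aminoethyl group on the same carbon would separate. They also leave open whether a carboxylic acid or a longer chain ending in hydroxyl at this place would behave in the same way.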